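The source may report more compounds than this note shows. Statements on the series, on what has been measured and on what is new or still open speak of the compounds shown alone.

Compound 1 `Cc1ccc(S(=O)(=O)/N=C(/CCNC2=CC(=O)c3ccccc3C2=O)Nc2ccc(Cl)cc2)cc1` is the starting point of this comparison. In a functional assay on DU-145 cells (Homo sapiens) for cytotoxicity, read by MTT assay, with a stated time of 48 h (on this read-out lower numbers stand for stronger inhibition and higher numbers for weaker inhibition), compound 1 gives 32400 nM, the lowest of the three numbers measured. Compound 2 `Cc1ccc(S(=O)(=O)/N=C(/CCNC2=CC(=O)c3ccccc3C2=O)Nc2cccc(C(F)(F)F)c2)cc1` gives 84100 nM in this assay, and compound 3 `COc1ccc(N/C(CCNC2=CC(=O)c3ccccc3C2=O)=N\S(=O)(=O)c2ccc(C)cc2)c(OC)c1` gives 67300 nM. Exchanging the aryl group on the amine nitrogen thus raised the number in both cases: a 2.6-fold higher number from compound 1 to compound 2 (0.41 log units; beyond the scatter) and a 2.1-fold higher number from compound 1 to compound 3 (0.32 log units; beyond the scatter). Between the two replacements themselves the gap was small: a 1.2-fold lower number from compound 2 to compound 3 (0.10 log units; within the scatter).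

Compound 4 `COc1cc(N/C(CCNC2=CC(=O)c3ccccc3C2=O)=N\S(=O)(=O)c2ccc(C)cc2)cc(OC)c1OC` has not yet been measured. It differs from compound 1 in one place: 3,4,5-trimethoxyphenyl in place of 4-chlorophenyl on an amine nitrogen. The step that bears most on this change is a 2.1-fold higher number from compound 1 to compound 3 (0.32 log units; beyond the scatter), where 2,4-dimethoxyphenyl replaced 4-chlorophenyl at the same amine nitrogen; the step of a 2.6-fold higher number from compound 1 to compound 2 (0.41 log units; beyond the scatter) points in the same direction and is of similar size. Compound 4 is therefore expected to show a modest rise, about a 1.9-fold higher number from compound 1 to compound 4 (0.27 log units; within the scatter). The estimate for compound 4 in this assay is 60000 nM, with a range from 25000 nM to 150000 nM.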

Compound 4, half-maximal inhibitory concentration: 9330 nM
Beside the measured number, compound 4's estimate is 6.4-fold (0.81 log units) above it, outside the stated range (below it).
By their numbers in this assay, from the lowest: compound 4; then compound 1; then compounds 3 and 2 (each within the scatter of the next).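

The 3,4,5-trimethoxyphenyl group shows that replacing 4-chlorophenyl at this amine nitrogen need not weaken the result in this assay: it gives a 3.5-fold lower number from compound 1 to compound 4 (0.54 log units; beyond the scatter), whereas both earlier replacements raised the number. Carrying methoxy groups on the aryl ring does not by itself decide the outcome, as the change from 2,4-dimethoxyphenyl to 3,4,5-trimethoxyphenyl gives a 7.2-fold lower number from compound 3 to compound 4 (0.86 log units; beyond the scatter), and the change from 3-(trifluoromethyl)phenyl gives a 9.0-fold lower number from compound 2 to compound 4 (0.95 log units; beyond the scatter). No measurement shown here explains why this group stands apart from the other three.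

The compounds shown leave open whether the lower number follows from how many methoxy groups the ring carries or from where they stand. They also leave open how a plain phenyl group, or ethoxy groups in place of the methoxy groups, would compare.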